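A few compounds are considered here, and "the series" means these few. Any claim that something is new, unique, unknown or untested is made for them only; others in the source may bear on it.

In a functional assay on HepG2 cells (Homo sapiens) for inhibition, read by MTT assay, with a stated time of 72 h (a higher number here means a weaker inhibitor, a lower number a stronger inhibitor), compound 2 `CN(C(=O)NC(=O)c1ccccc1F)c1nc(C(F)(F)F)c(C(=O)N/N=C/c2cccc(C(F)(F)F)c2)s1` gives 20.3 ug/mL, and compound 3 `CN(C(=O)NC(=O)c1ccccc1F)c1nc(C(F)(F)F)c(C(=O)N/N=C/c2ccc(C(F)(F)F)cc2)s1` gives 4.56 ug/mL. The change 4-(trifluoromethyl)phenyl in place of 3-(trifluoromethyl)phenyl on a carbon with a double bond to nitrogen brings a 4.5-fold lower number from compound 2 to compound 3 (0.65 log units; beyond the scatter). Compound 1 `CNc1nc(C(F)(F)F)c(C(=O)N/N=C/c2cccc(C(F)(F)F)c2)s1` is reported in this assay only as a limit, > 100 ug/mL. The change hydrogen in place of ((2-fluorophenyl)carbonyl)carbamoyl on a nitrogen on an aromatic ring thus brings an at least 4.9-fold higher number from compound 2 to compound 1 (0.69 log units; beyond the scatter), the size of that step being open because of the limit of > 100 ug/mL in this assay, at which 1 of the 3 values shown sits.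

Compound 4 `CNc1nc(C(F)(F)F)c(C(=O)N/N=C/c2ccc(C(F)(F)F)cc2)s1` carries the same change relative to compound 3: hydrogen in place of ((2-fluorophenyl)carbonyl)carbamoyl on a nitrogen on an aromatic ring, at a place described in the same words as in the move from compound 2 to compound 1. Among the measured compounds shown here, compound 4 is expected to show a 9.9-fold higher number from compound 3 to compound 4 (0.99 log units; beyond the scatter), since the one measured instance of this change, from compound 2 to compound 1, gave an at least 4.9-fold higher number from compound 2 to compound 1 (0.69 log units; beyond the scatter). Compound 4 is therefore estimated at 45 ug/mL, with a range from 15 ug/mL to 150 ug/mL, and a fair chance that this assay again returns only a limit.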

Compound 4, half-maximal inhibitory concentration: > 100 ug/mL
Compound 4: no number, only a limit; the forecaster's own chance of this, stated with the estimate: 35%; middle value at least 2.2-fold (0.34 log units) from the limit.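

The change to hydrogen in place of ((2-fluorophenyl)carbonyl)carbamoyl gives, in this assay, an at least 21-fold higher number from compound 3 to compound 4 (1.34 log units; beyond the scatter). Both compounds that carry the hydrogen return a limit and not a number, yet the change raises the number on both cores: the same change on two cores in this assay, an at least 4.9-fold higher number (0.69 log units; beyond the scatter) from compound 2 to compound 1 and an at least 21-fold higher number (1.34 log units; beyond the scatter) from compound 3 to compound 4; the limit leaves it open whether they differ. So the direction of the change carries from one core to the other, but its true size on either core is not shown: the limit of > 100 ug/mL in this assay, at which 2 of the 4 values shown sit.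

The compounds shown leave open whether an acetyl or an unsubstituted benzoylcarbamoyl group on that nitrogen would serve as well as ((2-fluorophenyl)carbonyl)carbamoyl. They also leave open what a chlorine or a methoxy group in place of the trifluoromethyl on the phenyl ring would do.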